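Clearance notes on a pyrrolidine sulfonamide pair

A few compounds are considered here, and "the series" means these few. Any claim that something is new, unique, unknown or untested is made for them only; others in the source may bear on it.

Measured in an ADME assay on the whole organism (Rattus norvegicus, strain Sprague-Dawley) for pharmacokinetics, read by LC-MS, with a stated time of 30 min, at a dose of 1 mg/kg by the intravenous route; on this read-out lower numbers stand for slow clearance and higher numbers for fast clearance:
compound 1 `N#Cc1ccc(O[C@H]2CN(S(=O)(=O)c3ccc(Cl)cc3Cl)C[C@@]2(O)CN)cc1F` gives 40 mL/min/kg
compound 2 `N#Cc1ccc(O[C@H]2CN(S(=O)(=O)c3ccc(Cl)cn3)C[C@@]2(O)CO)cc1F` gives 30 mL/min/kg

Of the two numbers seen, compound 2 sits at one end, and compound 1 lies within the scatter of it, so the two read as the same clearance. Compound 3 `N#Cc1ccc(O[C@H]2CN(S(=O)(=O)c3ccc(Cl)cn3)C[C@@]2(O)CN)cc1F` is the unmeasured partner of compound 2, carrying (amino in place of hydroxy on a saturated chain carbon bound to a saturated ring carbon). Going by the values given here, no step between measured compounds isolates this change, and the two measured compounds show no gap beyond the scatter, so for compound 3 a step in this assay of a 1.2-fold higher number from compound 2 to compound 3 (0.07 log units; within the scatter) is expected, none beyond the scatter. Compound 3 is estimated at 35 mL/min/kg, with a range of 18 mL/min/kg to 70 mL/min/kg.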

Compound 3, clearance: 45 mL/min/kg
Compound 3: middle estimate off by 1.3-fold (0.11 log units), on the low side; the measured number falls inside the stated range.
By their numbers in this assay, from the lowest: compounds 2, 1 and 3 (each within the scatter of the next).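

In this assay the change from hydroxymethyl to aminomethyl, now isolated in a single pair, gives a 1.5-fold higher number from compound 2 to compound 3 (0.18 log units; within the scatter) and so leaves clearance unmoved at this position. The other place, 5-chloropyridin-2-yl in place of 2,4-dichlorophenyl on a sulfonyl sulfur, gives a 1.1-fold higher number from compound 1 to compound 3 (0.05 log units; within the scatter) with the aminomethyl held, so neither change moves the number beyond the scatter.

As far as these compounds go, whether a carboxylic acid or a longer chain such as aminoethyl at this position would stay as flat remains open. No measured evidence bears on why these steps stay small.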